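From pyridin-2-yl to pyridin-3-yl at the assay limit

The compounds below may be only part of what the source reports. "The series", "measured", "known", "first", "only" and "open" are said of these compounds alone.

Measured compounds, with each value a limit and not a number:
Compound 1 `O=C(Nc1ccc(Cl)c(-c2nnc3c(Cl)cccn23)c1)c1ccc(C(F)(F)F)cc1Cl`: > 100000 nM
Compound 2 `O=C(Nc1ccc(Cl)c(-c2nnc3c(Cl)cccn23)c1)c1ccccn1`: > 100000 nM

Both compounds were tested in a functional assay on A549 cells (Homo sapiens) for antiproliferative activity, read by MTT assay, with a stated time of 72 h; a lower number here means a stronger inhibitor, a higher number a weaker inhibitor. The full record so far is the limit of > 100000 nM in this assay, at which 2 of the 2 values shown sit. Compound 2 therefore stands at a limit, > 100000 nM, and has no measured number. Compound 1 likewise stands at a limit, > 100000 nM. Among the compounds with values here, neither compound can be ranked against the other, and no measured pair yet shows the size of a single structural change in this assay.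

The next compound is compound 3 `O=C(Nc1ccc(Cl)c(-c2nnc3c(Cl)cccn23)c1)c1cccnc1`, which keeps the rest of compound 2 unchanged. The change is pyridin-3-yl in place of pyridin-2-yl on a carbonyl carbon. With only limits to go on, the expectation rests on compound 2 at > 100000 nM, and no shift beyond the usual scatter is foreseen. The expected step is a number no higher from compound 2 to compound 3 (the limit leaves the size open), with no favoured direction. For compound 3 the estimated value is 100000 nM, with an expected range from 30000 nM to 200000 nM.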

Compound 3, half-maximal inhibitory concentration: > 100000 nM
Compound 3 gave a limit, no number; the forecaster's own chance of this, stated with the estimate: 70%; the middle value lies on the limit itself.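

In this assay compound 3 gives > 100000 nM, a limit and not a number. Compound 2 also stands at a limit, so no step can be read between compound 2 and compound 3. The compounds shown leave open whether pyridin-3-yl and pyridin-2-yl differ at all in this assay, and the record offers no number yet: the limit of > 100000 nM in this assay, at which 3 of the 3 values shown sit.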